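Swapping a Fluorinated Aryl Ring for a Pyridine

A few compounds are considered here, and "the series" means these few. Any claim that something is new, unique, unknown or untested is made for them only; others in the source may bear on it.

In a functional assay on HT-29 cells (Homo sapiens) for antiproliferative activity, read by MTT assay, with a stated time of 24 h (on this read-out higher numbers stand for weaker inhibition and lower numbers for stronger inhibition), compound 1 `COc1ccc(C(=O)/C=C/c2cc(OC)c(OC)c(OC)c2)c2c1C=CC(C)(C)O2` gives only a limit of > 10000 nM, not a number. Compound 2 `COc1ccc(/C=C/C(=O)c2ccc(OC)c3c2OC(C)(C)C=C3)c(F)c1` likewise gives only a limit of > 10000 nM in this assay. Going by the values given here, both results sit at the limit of > 10000 nM in this assay, at which 2 of the 2 values shown sit, so compound 2 stands at the edge of what this assay can report, and no measured step exists to weigh. Compound 3 `COc1ccc(C(=O)/C=C/c2ccccn2)c2c1C=CC(C)(C)O2` carries pyridin-2-yl in place of 2-fluoro-4-methoxyphenyl on a double-bonded chain carbon bound to a double-bonded chain carbon. With nothing measured inside the range of this assay, no direction can be read, and the expected step is a step that the limit leaves unreadable from compound 2 to compound 3. Compound 3 is estimated at 15000 nM, within 3000 nM to 60000 nM in this assay.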

Compound 3, half-maximal inhibitory concentration: 2120 nM
Estimate against measurement, compound 3: 7.1-fold (0.85 log units) above, outside the stated range (below it).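

With pyridin-2-yl in place of 2-fluoro-4-methoxyphenyl on a double-bonded chain carbon bound to a double-bonded chain carbon, this assay shows an at least 4.7-fold lower number from compound 2 to compound 3 (0.67 log units; beyond the scatter). This change therefore moves the result into the range the assay can read, so the group at this place matters for activity. The value for compound 2 is a limit and not a number, so the step gives only a minimum size: the limit of > 10000 nM in this assay, at which 2 of the 3 values shown sit.

The shown compounds do not separate the effect of the ring nitrogen from the loss of the fluorine and methoxy groups. A plain phenyl ring or a pyridin-3-yl group at this place could separate them.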